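A few compounds are considered here, and "the series" means these few. Any claim that something is new, unique, unknown or untested is made for them only; others in the source may bear on it.

Measured compounds in a functional assay on PC-12 cells (Rattus norvegicus) for cytotoxicity, read by MTT assay, with stated times of 2 h and 24 h, tested at 5 uM; on this read-out higher numbers stand for a stronger effect at the one concentration tested and lower numbers for a weaker effect:
compound 1 `Oc1cc(C(F)(F)F)ccc1-c1nc(-c2ccccc2O)n(-c2ccc(OC(F)(F)F)cc2)n1`: 84.9%
compound 2 `Oc1cc(C(F)(F)F)ccc1-c1nc(-c2ccccc2O)n(-c2ccccc2Cl)n1`: 90.6%
compound 3 `Oc1cc(C(F)(F)F)ccc1-c1nc(-c2ccccc2O)n(-c2ccccc2C(F)(F)F)n1`: 80%

Compound 3 has the lowest of the three numbers. Its nearest neighbour is compound 1, and that gap, a number 4.9 percentage points lower from compound 1 to compound 3 (within the scatter), is within the scatter; the gap to compound 2, a number 10.6 percentage points lower from compound 2 to compound 3 (beyond the scatter), is beyond the scatter, though modest. Compound 1 and compound 2 lie within the scatter of each other, a number 5.7 percentage points higher from compound 1 to compound 2 (within the scatter).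

Compound 4 `Oc1cc(C(F)(F)F)ccc1-c1nc(-c2ccccc2O)n(-c2ccc(Cl)cc2Cl)n1` has not yet been measured in this assay. The change from compound 3 is 2,4-dichlorophenyl in place of 2-(trifluoromethyl)phenyl on an aromatic nitrogen. Within the data shown here, the measured step that bears most directly on it is the swap of chloro for trifluoromethyl on an aromatic carbon, a number 10.6 percentage points lower from compound 2 to compound 3 (beyond the scatter), which compound 4 reverses while adding a second chloro; the 2,4-dichlorophenyl group itself has no measured counterpart, so the added chloro is uncharted. The expected step is therefore upward, of roughly the size seen from compound 2 to compound 3, with wide uncertainty. For compound 4 in this assay the expected value is 88%, between 78% and 96%. The estimated step is a number 8 percentage points higher from compound 3 to compound 4 (within the scatter).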

Compound 4, a percentage reported as activity, at one concentration (the size of the read-out at that concentration, not a potency): 86.7%
The estimate for compound 4 lay 1.3 percentage points above the measured number; the measured number falls inside the stated range.
By their numbers in this assay, from the lowest: compounds 3, 1, 4 and 2 (each within the scatter of the next, the first and the last beyond it).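

On the aryl group at the aromatic nitrogen, chloro in place of hydrogen on an aromatic carbon gives a number 3.9 percentage points lower from compound 2 to compound 4 (within the scatter) in this assay, so the step from 2-chlorophenyl to 2,4-dichlorophenyl does not separate the two compounds on this read-out. Among these compounds, the other two swaps at this place, a number 6.7 percentage points higher from compound 3 to compound 4 (within the scatter) and a number 1.8 percentage points higher from compound 1 to compound 4 (within the scatter), also stay inside the scatter, so 2,4-dichlorophenyl cannot be told apart from 2-(trifluoromethyl)phenyl or 4-(trifluoromethoxy)phenyl here, although the one step beyond the scatter, a number 10.6 percentage points lower from compound 2 to compound 3 (beyond the scatter), still separates the two groups that carry a single substituent at the same place. Nothing available gives a reason for these numbers.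

The compounds shown leave open whether the read-out at this place would move clear of the scatter with an amine or a carboxylic acid on the phenyl ring, or with a cyclohexyl group in place of that ring. On these data alone, with one concentration and one shared core throughout, the numbers give no potency, and whether these groups would stand the same way on another core stays unknown.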